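The compounds below may be only part of what the source reports. "The series", "measured", "known", "first", "only" and "open" are said of these compounds alone.

Measured so far in a functional assay on SGC-7901 cells (Homo sapiens) for antiproliferative activity, read by MTT assay, with a stated time of 24 h; a lower number here means a stronger inhibitor, a higher number a weaker inhibitor:
- compound 1 `Cc1ccccc1NNC(=O)c1ccc(NS(=O)(=O)c2cnc(O)nc2O)cc1`: > 20000 nM (a limit)
- compound 2 `O=C(NNc1cccc(Cl)c1)c1ccc(NS(=O)(=O)c2cnc(O)nc2O)cc1`: 11600 nM
- compound 3 `Cc1ccccc1C(=O)NNC(=O)c1ccc(NS(=O)(=O)c2cnc(O)nc2O)cc1`: > 20000 nM (a limit)

Compound 3 gives only a limit, > 20000 nM. Compound 1 and compound 3 share (the limit of > 20000 nM in this assay, at which 2 of the 3 values shown sit). No number is therefore available as a starting point for the next step.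

Compound 4 `O=C(NNC(=O)c1cccc(Cl)c1)c1ccc(NS(=O)(=O)c2cnc(O)nc2O)cc1` keeps the carbonyl of compound 3 and exchanges one group: 3-chlorophenyl in place of 2-methylphenyl on a carbonyl carbon. In words, this is 3-chlorophenyl in place of 2-methylphenyl on a carbonyl carbon.

The nearest measured precedent is the same exchange on an amine nitrogen: an at least 1.7-fold lower number from compound 1 to compound 2 (0.23 log units; that floor lies within the scatter). Only a floor is known for that step, and it lies within the scatter. The other readable step, an at least 1.7-fold higher number from compound 2 to compound 3 (0.23 log units; that floor lies within the scatter), is also a floor within the scatter, and it changes the group on the amine nitrogen rather than the exchange in question. The remaining one, a step that the two limits leave unreadable from compound 1 to compound 3, gives no size.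

On this evidence, a modest move towards a lower number in this assay is expected, possibly none beyond the scatter, and another limit would be no surprise. The expected change is an at least 1.2-fold lower number from compound 3 to compound 4 (0.09 log units; that floor lies within the scatter). For compound 4 the estimated value is 16000 nM, with an expected range from 8000 nM to 32000 nM.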

Compound 4, half-maximal inhibitory concentration: 8610 nM
Compound 4: middle estimate off by 1.9-fold (0.27 log units), on the high side; the range from low to high includes it.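

In this assay the exchange on a carbonyl carbon gives an at least 2.3-fold lower number from compound 3 to compound 4 (0.36 log units; beyond the scatter). Among the compounds shown here, this is the first floor for 3-chlorophenyl in place of 2-methylphenyl that clears the scatter, since the same exchange on an amine nitrogen left a floor within it. With 3-chlorophenyl held, the carbonyl makes no readable difference: a 1.3-fold lower number from compound 2 to compound 4 (0.13 log units; within the scatter). The comparison with the other 2-methylphenyl compound, an at least 2.3-fold lower number from compound 1 to compound 4 (0.36 log units; beyond the scatter), is also a floor, and so is the step on the carbonyl carbon, because both start from a limit of the assay: the limit of > 20000 nM in this assay, at which 2 of the 4 values shown sit.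

The exchange replaces 2-methylphenyl with 3-chlorophenyl in a single move, so the compounds shown leave open how plain phenyl, or a phenyl ring bearing a methoxy group or a nitrile, would read on the same carbonyl carbon. Also open, from the compounds shown here alone, is whether an amine or a carboxylic acid on that ring would take the series further from the limit, and whether the amine nitrogen and carbonyl forms would still read alike with those groups.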